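Adding a Dimethoxyphenyl Group: What to Expect

This account rests on a few compounds, and the source may have more. Where it says the series, first, only, none or still open, it means among the compounds named here.

Of the compounds shown here, three that share a common core have been measured in a functional assay on PC-12 cells (Rattus norvegicus) for cytotoxicity, read by MTT assay, with stated times of 3 h and 2 h, tested at 20 uM; on this read-out higher numbers stand for a stronger effect at the one concentration tested and lower numbers for a weaker effect. Compound 1 `O=C(CCCCC1CCSS1)NCc1cn(CCCOc2ccc3cc(C(=O)O)c(=O)oc3c2)nn1` gives 66.8%. Compound 2 `O=C(CCCCC1CCSS1)NCc1cn(CCCCOc2ccc3cc(-c4ccc(Cl)c(Cl)c4)c(=O)oc3c2)nn1` gives 62.9%. Compound 3 `O=C(CCCCC1CCSS1)NCc1cn(CCCCCOc2ccc3ccc(=O)oc3c2)nn1` gives 78.5%, the highest of the three numbers; its lead over compound 1 and over compound 2 lies beyond the usual scatter of repeated measurements of this kind, so compound 3 can be called the strongest of the three in this assay.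

Compound 4 `COc1ccc(-c2cc3ccc(OCCCCCn4cc(CNC(=O)CCCCC5CCSS5)nn4)cc3oc2=O)cc1OC` has not yet been measured. It differs from compound 3 in one place: 3,4-dimethoxyphenyl in place of hydrogen on an aromatic carbon. Among the compounds with values here, no pair of measured compounds differs by exactly this kind of change, so there is no direct step to lean on. Compound 2 also carries an aromatic ring on its core, but it differs from compound 3 in more than one place; all that can be said is that compound 2 gives a lower number than compound 3.

With that as the only hint, a modest downward move in this assay is expected for the step of a number 10.5 percentage points lower from compound 3 to compound 4 (beyond the scatter). Compound 4 is therefore estimated to give about 68%, with a likely range from 52% to 84%.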

Compound 4, a percentage reported as activity, at one concentration (the size of the read-out at that concentration, not a potency): 51.9%
Beside the measured number, compound 4's estimate is 16.1 percentage points above it; measured number outside the range, below it.
By their numbers in this assay, from the lowest: compound 4; then compounds 2 and 1 (each within the scatter of the next); then compound 3.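

In this assay, within the data shown here, the effect of filling this position can now be read directly for the first time, since compound 3 and compound 4 differ in this one place only. Putting 3,4-dimethoxyphenyl in place of hydrogen, on an aromatic carbon two atoms from the ring oxygen, gives a number 26.6 percentage points lower from compound 3 to compound 4 (beyond the scatter), so this position is not indifferent to substitution: a group of this size, with one aromatic ring and two hydrogen-bond acceptors, goes with a clearly weaker effect at the one concentration tested. The data at hand contain no separate measurement that accounts for this drop.

This single step cannot separate the contribution of the added aromatic ring from that of its two methoxy groups, and an unsubstituted phenyl ring on the same carbon, with the rest of compound 3 unchanged, would be needed to tell them apart. Going by these compounds, it also remains open whether a much smaller group there, such as a methyl or an amine, would move the number at all, or whether the loss appears only with a whole added ring.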